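Swapping the piperazine amide for a plain phenyl

The source may report more compounds than this note shows. Statements on the series, on what has been measured and on what is new or still open speak of the compounds shown alone.

Measured so far:
compound 1 `COc1ccc(-c2cnc3nc(N)nc(N4CCN(c5ccc(F)cc5)CC4)c3n2)cc1OC`: 100 nM
compound 2 `COc1ccc(-c2cnc3nc(N)nc(N4CCN(C(=O)CCc5ccccc5)CC4)c3n2)cc1OC`: 100 nM
compound 3 `COc1ccc(-c2cnc3nc(N)nc(N4CCN(C(=O)COc5ccc(Cl)cc5)CC4)c3n2)cc1OC`: 0.5 nM

In a functional assay on cells (T-cell, Homo sapiens) for inhibition (on this read-out lower numbers stand for stronger inhibition and higher numbers for weaker inhibition), compound 3 gives the lowest number of the three; the nearest is compound 1 at a 200-fold lower number from compound 1 to compound 3 (2.30 log units; beyond the scatter), and compound 2 sits at a 200-fold lower number from compound 2 to compound 3 (2.30 log units; beyond the scatter). Compound 4 `COc1ccc(-c2cnc3nc(N)nc(N4CCN(c5ccccc5)CC4)c3n2)cc1OC` differs from compound 3 by phenyl in place of ((4-chlorophenoxy)methyl)carbonyl on an amine nitrogen in a ring. The relevant steps are a 200-fold lower number from compound 1 to compound 3 (2.30 log units; beyond the scatter) and a 200-fold lower number from compound 2 to compound 3 (2.30 log units; beyond the scatter), both large, while no change at the digits printed from compound 1 to compound 2 (within the scatter). Compound 4 resembles compound 1, which carries an aromatic ring directly on that nitrogen, so a large loss is expected going back. The expected step is a 200-fold higher number from compound 3 to compound 4 (2.30 log units; beyond the scatter). Compound 4 is estimated at 100 nM, within 30 nM to 400 nM.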

Compound 4, half-maximal inhibitory concentration: 400 nM
Compound 4: middle estimate off by 4.0-fold (0.60 log units), on the low side; the range from low to high includes it.
By their numbers in this assay, from the lowest: compound 3; then compounds 1 and 2 (each within the scatter of the next); then compound 4.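

In this assay, phenyl on this ring nitrogen falls far short of the ((4-chlorophenoxy)methyl)carbonyl group, with an 800-fold higher number from compound 3 to compound 4 (2.90 log units; beyond the scatter) at this position. Replacing phenethylcarbonyl with phenyl costs much less, at a 4.0-fold higher number from compound 2 to compound 4 (0.60 log units; beyond the scatter) here, and replacing the fluoro with hydrogen on the aromatic ring gives a 4.0-fold higher number from compound 1 to compound 4 (0.60 log units; beyond the scatter) as well, so even this small change registers. No measurement shown explains these differences.

Going by these compounds, whether a benzyl group or a pyridine ring on this nitrogen would restore strength remains open. So does the separate contribution of the ether oxygen and the chloro in compound 3.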